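Notes on the aryl swap from compound 2 to compound 3

The compounds below may be only part of what the source reports. "The series", "measured", "known", "first", "only" and "open" are said of these compounds alone.

Compound 2 `c1c[nH]c(-c2ccccc2OCC2=NCCN2)c1` is measured in a functional assay for activation of Alpha-1D adrenergic receptor (Homo sapiens), read by calcium flux (a higher number here means that more compound is needed for the effect, a lower number that less compound is needed), where compound 2 gives 6.31 nM; this is the only number shown in the series. Compound 1 `Cc1cccnc1-c1ccccc1OCC1=NCCN1` gives only a limit in this assay, < 100000 nM. For the measured compounds named here, no step between two measured compounds is available, so nothing is known here about the size of effect of any single change in this assay. Compound 3 `Cc1cnsc1-c1ccccc1OCC1=NCCN1` has not yet been measured. It differs from compound 2 by 4-methyl-1,2-thiazol-5-yl in place of 1H-pyrrol-2-yl on an aromatic carbon. For this assay a step from compound 2 to compound 3 is expected that goes beyond the scatter, in the direction of more compound being needed, estimated at a 48-fold higher number from compound 2 to compound 3 (1.68 log units; beyond the scatter). Compound 3 is accordingly estimated at 300 nM, with a range from 30 nM to 5000 nM.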

Compound 3, half-maximal effective concentration: < 100000 nM
Compound 3: a limit, no number; the forecaster's own chance of this, stated with the estimate: 5%; the middle value does not contradict the limit.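

In this assay, for the compounds shown here, compound 3 gives only a limit, < 100000 nM, so no step from compound 2 to compound 3 can be read. The compounds shown leave open how large the change from 1H-pyrrol-2-yl to 4-methyl-1,2-thiazol-5-yl is in this assay.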